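Oxolan-3-yl to oxan-3-yl on a carbonyl carbon

This account rests on a few compounds, and the source may have more. Where it says the series, first, only, none or still open, it means among the compounds named here.

Measured so far in a physicochemical assay for solubility, read by mass spectrometry, in phosphate buffer, with a stated time of 24 h, at pH 7.4; on this read-out higher numbers stand for higher solubility and lower numbers for lower solubility (solubility values):
compound 1 `Cc1occc1C(=O)N1CCC(NC(=O)Nc2ccc(C(F)(F)F)cc2)CC1` gives 0.28 ug/mL
compound 2 `O=C(Nc1ccc(OC(F)(F)F)cc1)NC1CCN(C(=O)C2CCOC2)CC1` gives 29 ug/mL
compound 3 `O=C(Nc1ccc(OC(F)(F)F)c(F)c1)NC1CCN(C(=O)N2CCOCC2)CC1` gives 96 ug/mL

Compound 2 (29 ug/mL) holds the second highest of the three numbers. Only compound 3 gives a higher number (96 ug/mL), and only compound 1 gives a lower one (0.28 ug/mL). Both gaps lie beyond the scatter.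

Compound 4 `O=C(Nc1ccc(OC(F)(F)F)cc1)NC1CCN(C(=O)C2CCCOC2)CC1` has not yet been measured in this assay and is the next point of interest. It differs from compound 2 in one place: oxan-3-yl in place of oxolan-3-yl on a carbonyl carbon. In words, oxan-3-yl stands in place of oxolan-3-yl on a carbonyl carbon.

Among the measured compounds shown here, the series offers no measured step between compounds that differ in one place. Compound 1 and compound 3 each differ from compound 2 in more than one place, so neither gives a direct measure of this change. The expectation therefore rests on compound 2 (29 ug/mL) and on the small size of the structural change. No step beyond the scatter is expected, with a slightly lower number as the more likely side.

This estimate means an expected 1.5-fold lower number from compound 2 to compound 4 (0.16 log units; within the scatter) and no more. Compound 4 is estimated at 20 ug/mL (expected range 7 ug/mL to 60 ug/mL).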

Compound 4, solubility: 94 ug/mL
Compound 4: the middle estimate sits 4.7-fold (0.67 log units) below what was measured; measured number above the stated range.
By their numbers in this assay, from the lowest: compound 1; then compound 2; then compounds 4 and 3 (each within the scatter of the next).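

In this assay, among the compounds shown here, this is the first change that can be read in one place: on a carbonyl carbon whose other neighbour is an amide-type nitrogen in a ring, oxan-3-yl in place of oxolan-3-yl gives a 3.2-fold higher number from compound 2 to compound 4 (0.51 log units; beyond the scatter) in a step that lies beyond the usual scatter. The earlier compounds shown here could not show that this position responds to ring size alone, since compound 1 and compound 3 each differ from compound 2 in more than one place. Here, a six-membered non-aromatic ring replaces a five-membered one, with one ring hetero atom, the same hydrogen-bond counts and no net charge on either side, and the number still moves upward. No measurement in hand accounts for this step.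

This single pair does not show whether the step would carry over to a different group elsewhere on the shared core. Going by these compounds, how the read-out would respond at this carbonyl carbon to oxan-4-yl, a piperidin-3-yl ring with its free amine, or an open methoxyethyl chain also remains open.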